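Changing the Aryl Group on a Shared Core

The source may report more compounds than this note shows. Statements on the series, on what has been measured and on what is new or still open speak of the compounds shown alone.

Three compounds here share one core and differ in the aryl group attached to it. In an assay on CHO-K1 cells for antagonist activity at adenosine receptor A1 (Homo sapiens), read by a beta-galactosidase reporter, with stated times of 15 min and 6 h (on this read-out higher numbers stand for weaker inhibition and lower numbers for stronger inhibition), compound 1 `Nc1nc(-c2ccco2)nc2sc(CN3CCC(=O)CC3)cc12` gives 2720 nM. In this assay compound 2 `N#Cc1ccccc1-c1nc(N)c2cc(CN3CCC(F)CC3)sc2n1` gives 5050 nM, the highest of the two numbers shown, with compound 1 nearest and within the usual scatter of it. In this assay compound 3 `Nc1nc(-c2ccccc2C(F)(F)F)nc2sc(CN3CCC(F)CC3)cc12` reads > 10000 nM, a limit of the assay rather than a number, so that compound 3 sits at the limit of > 10000 nM in this assay, at which 1 of the 3 values shown sits. For the measured compounds named here, the only measured step that alters the aryl group is an at least 1.9-fold higher number from compound 2 to compound 3 (0.29 log units; that floor lies within the scatter), and its floor lies within the scatter.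

Compound 4 `COc1cccc(-c2nc(N)c3cc(CN4CCC(F)CC4)sc3n2)c1` is not yet measured and differs from compound 2 by 3-methoxyphenyl in place of 2-cyanophenyl on an aromatic carbon. Going by the values given here, because the one comparable step, an at least 1.9-fold higher number from compound 2 to compound 3 (0.29 log units; that floor lies within the scatter), gives no clear direction, compound 4 is expected to stay near compound 2, with any shift of modest size either way. The estimate for compound 4 in this assay is 5000 nM, within a range from 1500 nM to 15000 nM, which means an expected step of a 1.0-fold lower number from compound 2 to compound 4 (0.00 log units; within the scatter).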

Compound 4, inhibition constant: 3220 nM
For compound 4 the middle estimate is 1.6-fold (0.19 log units) above the measured one; the measured number falls inside the stated range.
By their numbers in this assay, from the lowest: compounds 1, 4 and 2 (each within the scatter of the next). At a limit, above all of these: compound 3.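

In this assay, 3-methoxyphenyl in place of 2-cyanophenyl gives a 1.6-fold lower number from compound 2 to compound 4 (0.20 log units; within the scatter). For the compounds shown here, this is the first change at this aromatic carbon of the shared core that can be read between two real numbers, and it shows that a nitrile and a methoxy group, each on a different ring position of the phenyl, leave the readings of the two compounds indistinguishable. The earlier step could not show this, since compound 3 remains a limit of the assay and not a number: the limit of > 10000 nM in this assay, at which 1 of the 4 values shown sits.

Both the group and its ring position changed in this one step, so 2-methoxyphenyl and 3-cyanophenyl would be needed to tell the two changes apart. As far as these compounds go, whether an unsubstituted phenyl, or a phenyl carrying an amine or a carboxylic acid, would read differently also remains open.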